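Replacing the 4-hydroxy-2-methylphenyl group of compound 2

This account rests on a few compounds, and the source may have more. Where it says the series, first, only, none or still open, it means among the compounds named here.

In a functional assay on T47D cells (Homo sapiens) for inhibition, read by sulforhodamine B assay, with a stated time of 48 h (a higher number here means a weaker inhibitor of growth, a lower number a stronger inhibitor of growth), compound 1 (`Cc1ccc(C2=NN(c3ccc(S(C)(=O)=O)cc3)C(=O)CC2)cc1`) gives 2080 nM and compound 2 (`Cc1cc(O)ccc1C1=NN(c2ccc(S(C)(=O)=O)cc2)C(=O)CC1`) gives 20200 nM as the higher of the two numbers, so compound 2 is the weaker inhibitor of growth of this pair. The gap between them is a 9.7-fold higher number from compound 1 to compound 2 (0.99 log units; beyond the scatter) and counts as modest.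

Compound 3 (`CCc1ccc(C2=NN(c3ccc(S(C)(=O)=O)cc3)C(=O)CC2)cc1`) has not yet been measured. It differs from compound 2 by one exchange, 4-ethylphenyl in place of 4-hydroxy-2-methylphenyl on a carbon with a double bond to nitrogen, and the count is 4-ethylphenyl in place of 4-hydroxy-2-methylphenyl on a carbon with a double bond to nitrogen for this change. For the measured compounds named here, only one measured step bears on it, the one that led from 4-methylphenyl to 4-hydroxy-2-methylphenyl, namely a 9.7-fold higher number from compound 1 to compound 2 (0.99 log units; beyond the scatter) in the upward direction. Going by the values given here, compound 3, like compound 1, carries no hydroxy group, but no measurement yet shows how 4-ethylphenyl compares with 4-methylphenyl. A step of similar size in the opposite direction is therefore expected in this assay and would be beyond the scatter. The estimate is an 8.1-fold lower number from compound 2 to compound 3 (0.91 log units; beyond the scatter) on these expected numbers. Compound 3 is expected to read 2500 nM within an estimated range of 800 nM to 7500 nM when measured.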

Compound 3, concentration for 50% growth inhibition: 4400 nM
For compound 3 the middle estimate is 1.8-fold (0.25 log units) below the measured one; the measured number falls inside the stated range.
By their numbers in this assay, from the lowest: compound 1; then compound 3; then compound 2.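

In this assay, the exchange of 4-hydroxy-2-methylphenyl for 4-ethylphenyl gives a 4.6-fold lower number from compound 2 to compound 3 (0.66 log units; beyond the scatter), so a group with no hydroxy at this carbon with a double bond to nitrogen again reads lower than compound 2, as the 4-methylphenyl group of compound 1 already did. The same exchange does not return the reading fully to that of compound 1: adding one carbon to the methyl gives a 2.1-fold higher number from compound 1 to compound 3 (0.33 log units; beyond the scatter), a modest step that is still beyond the scatter, and the first sign that the chain on this ring bears on growth inhibition. Among these three compounds, the two without a hydroxy group are therefore the stronger inhibitors of growth, and the shorter chain of compound 1 reads lowest.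

The compounds shown leave open how much of the weaker reading of compound 2 belongs to its hydroxy group and how much to the methyl of its 4-hydroxy-2-methylphenyl group, and whether a propyl chain or a methoxy group in place of the ethyl of compound 3 would read higher or lower. Nothing measured here says why these groups read differently.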